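Replacing the hydroxy of compound 2 on its carbonyl carbon

This account rests on a few compounds, and the source may have more. Where it says the series, first, only, none or still open, it means among the compounds named here.

Compound 1 `CCOC(=O)c1ccc(Oc2ccc(C#N)cc2)cc1`: limit of > 20000 nM
Compound 2 `COc1ccc(Oc2ccc(C(=O)O)cc2)cc1F`: limit of > 30000 nM

In a functional assay on HL-60 cells (Homo sapiens) for antiproliferative activity (on this read-out lower numbers stand for stronger inhibition and higher numbers for weaker inhibition), compound 2 stands only at a limit, > 30000 nM. Compound 1 also gives only a limit, > 20000 nM. Compound 3 `COc1ccc(Oc2ccc(C(=O)N(C)OC)cc2)cc1F` carries methoxy(methyl)amino in place of hydroxy on a carbonyl carbon. Going by the values given here, no measured step shows what such a change does in this assay. The expectation therefore rests on compound 2 and its limit of > 30000 nM. The expected change is none beyond the scatter, with an estimated at least 1.2-fold lower number from compound 2 to compound 3 (0.07 log units; that floor lies within the scatter). For compound 3 the estimate is 25000 nM, with an expected range of 9000 nM to 60000 nM.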

Compound 3, half-maximal inhibitory concentration: > 30000 nM
Compound 3: only a limit was reported; the forecaster's own chance of this, stated with the estimate: 65%; at least 1.2-fold (0.07 log units) between middle value and limit.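

Compound 2 and compound 3 both stand only at limits in this assay, so no step between them can be read: the limit of > 30000 nM in this assay, at which 2 of the 3 values shown sit.

The compounds shown leave open whether methoxy(methyl)amino in place of hydroxy on a carbonyl carbon changes the read-out at all.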